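Methoxy for methylsulfanyl on a quinoline-free core? No: a urea series

A few compounds are considered here, and "the series" means these few. Any claim that something is new, unique, unknown or untested is made for them only; others in the source may bear on it.

Compounds measured so far:
compound 1, `CSc1ccc(NC(=O)Nc2cc(C)nc3ccccc23)cc1`, > 25000 nM
compound 2, `CSc1ccccc1NC(=O)Nc1cc(C)nc2ccccc12`, > 25000 nM
compound 3, `Cc1cc(NC(=O)Nc2ccc([N+](=O)[O-])c(C(F)(F)F)c2)c2ccccc2n1`, > 25000 nM

In an ADME assay on Raji cells (Homo sapiens) for cytotoxicity, with a stated time of 72 h (on this read-out lower numbers stand for an effect already at smaller amounts and higher numbers for an effect only at larger amounts of compound), compound 1 gives only a limit of the assay, > 25000 nM, and not a number. Compound 2 likewise gives a limit, > 25000 nM. Compound 3 also gives a limit, > 25000 nM. So compound 1 stands at the limit of > 25000 nM in this assay, at which 3 of the 3 values shown sit, with nothing among the measured compounds to rank it against.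

Compound 4, `COc1ccc(NC(=O)Nc2cc(C)nc3ccccc23)cc1`, has not yet been measured in this assay. It differs from compound 1 in one place: methoxy in place of methylsulfanyl on an aromatic carbon.

With every measured value sitting at the limit, the step from compound 1 to compound 4 is expected to be none beyond the scatter, that is a step that the limit leaves unreadable from compound 1 to compound 4. Compound 4 is therefore expected to give about 30000 nM, with a range from 12000 nM to 80000 nM, most likely again reported only as a limit.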

Compound 4, half-maximal effective concentration: > 25000 nM
Compound 4 ended at the assay's limit; the forecaster's own chance of this, stated with the estimate: 85%; the middle value is on the limit's open side.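

In this assay compound 4 gives > 25000 nM, a limit and not a number. Among these compounds, compound 1 gives > 25000 nM, also a limit, so no step between compound 1 and compound 4 can be read. The compounds shown leave open whether methoxy and methylsulfanyl differ here at all.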